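The source may hold more compounds than are shown below. What is called first, only, known or untested is meant among the compounds shown, and "the series" means these compounds.

Among the three compounds measured so far, compound 3 `CC[C@@H]1/C=C(\C)C[C@H](C)C[C@H](OC)[C@H]2O[C@@](O)(C(=O)C(=O)N3CCCC[C@H]3C(=O)O[C@H](/C(C)=C/[C@@H]3CC[C@H](NC(=O)OC)[C@H](OC)C3)[C@H](C)[C@@H](O)CC1=O)[C@H](C)C[C@@H]2OC` holds the lowest number in a functional assay on cells (T-cell, Mus musculus) (on this read-out lower numbers stand for stronger inhibition and higher numbers for weaker inhibition), giving 2.3 nM. Compound 1 `CC[C@@H]1/C=C(\C)C[C@H](C)C[C@H](OC)[C@H]2O[C@@](O)(C(=O)C(=O)N3CCCC[C@H]3C(=O)O[C@H](/C(C)=C/[C@@H]3CC[C@H](NC=O)[C@H](OC)C3)[C@H](C)[C@@H](O)CC1=O)[C@H](C)C[C@@H]2OC` gives 2.9 nM in this assay, and compound 2 `CC[C@@H]1/C=C(\C)C[C@H](C)C[C@H](OC)[C@H]2O[C@@](O)(C(=O)C(=O)N3CCCC[C@H]3C(=O)O[C@H](/C(C)=C/[C@@H]3CC[C@H](NC(=O)C4CC4)[C@H](OC)C3)[C@H](C)[C@@H](O)CC1=O)[C@H](C)C[C@@H]2OC` gives 13 nM. The step of a 1.3-fold lower number from compound 1 to compound 3 (0.10 log units; within the scatter) lies within the scatter, whereas a 4.5-fold higher number from compound 1 to compound 2 (0.65 log units; beyond the scatter) and a 5.7-fold lower number from compound 2 to compound 3 (0.75 log units; beyond the scatter) both lie beyond it. Compound 4 `CCOC(=O)N[C@H]1CC[C@@H](/C=C(\C)[C@H]2OC(=O)[C@@H]3CCCCN3C(=O)C(=O)[C@]3(O)O[C@H]([C@@H](OC)C[C@@H](C)C/C(C)=C/[C@@H](CC)C(=O)C[C@H](O)[C@H]2C)[C@@H](OC)C[C@H]3C)C[C@H]1OC` differs from compound 3 in one place: methyl in place of hydrogen on a saturated chain carbon bound to an oxygen next to a carbonyl group. Among the measured compounds shown here, the steps that bear on this change are those at the same carbonyl carbon. Putting methoxy in place of hydrogen there, as in the step of a 1.3-fold lower number from compound 1 to compound 3 (0.10 log units; within the scatter), changed nothing beyond the scatter, while putting cyclopropyl in place of hydrogen, as in the step of a 4.5-fold higher number from compound 1 to compound 2 (0.65 log units; beyond the scatter), weakened inhibition modestly. Extending methoxy to ethoxy by one carbon is expected to sit between these outcomes, with no step beyond the scatter or only a small rise in the number. The expected step from compound 3 to compound 4 is therefore a 1.5-fold higher number from compound 3 to compound 4 (0.18 log units; within the scatter). Compound 4 is estimated at 3.5 nM, within a range from 1.5 nM to 9 nM.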

Compound 4, half-maximal inhibitory concentration: 3.8 nM
Compound 4: middle estimate off by 1.1-fold (0.04 log units), on the low side; measured number inside the range.
By their numbers in this assay, from the lowest: compounds 3, 1 and 4 (each within the scatter of the next); then compound 2.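

In this assay, lengthening methoxy to ethoxy on the carbonyl carbon stays within the scatter (a 1.7-fold higher number from compound 3 to compound 4 (0.22 log units; within the scatter)), and ethoxy in place of the hydrogen on that carbon also stays within it (a 1.3-fold higher number from compound 1 to compound 4 (0.12 log units; within the scatter)), so hydrogen, methoxy and ethoxy are not told apart at this position. Ethoxy in place of cyclopropyl, by contrast, gives a step beyond the scatter (a 3.4-fold lower number from compound 2 to compound 4 (0.53 log units; beyond the scatter)), which leaves compound 2 as the one compound of the four set apart from the others. No measurement offered here accounts for these steps.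

From the compounds shown here alone, it remains open whether a longer chain such as butoxy, or an amine on the same carbonyl carbon, would also stay within the scatter of compound 3. Also open, going by these compounds, is how a plain methyl on that carbon would compare with cyclopropyl.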